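A few compounds are considered here, and "the series" means these few. Any claim that something is new, unique, unknown or untested is made for them only; others in the source may bear on it.

Compound 1 `Cc1cc(NC(=O)Nc2cccc(Cl)c2)c2ccccc2n1`: in an ADME assay on HEK293 cells (Homo sapiens) for cytotoxicity, with a stated time of 72 h (on this read-out lower numbers stand for an effect already at smaller amounts and higher numbers for an effect only at larger amounts of compound), compound 1 gives 21000 nM.
Compound 2 `Cc1cc(NC(=O)Nc2cccc(C(N)=O)c2)c2ccccc2n1`: in this assay compound 2 reaches only the limit > 25000 nM.
Compound 3 `Cc1cc(NC(=O)Nc2ccc(Cl)cc2)c2ccccc2n1`: in this assay compound 3 also reaches only the limit > 25000 nM.

Compound 3 thus stands at the limit of > 25000 nM in this assay, at which 2 of the 3 values shown sit, and no number is known for it. Compound 4 `Cc1cc(NC(=O)Nc2cccc(F)c2)c2ccccc2n1` differs from compound 3 by 3-fluorophenyl in place of 4-chlorophenyl on an amide-type nitrogen. For the measured compounds named here, two measured steps bear on this. The step of an at least 1.1-fold higher number from compound 1 to compound 3 (0.07 log units; that floor lies within the scatter), 4-chlorophenyl in place of 3-chlorophenyl on an amide-type nitrogen, ended at the limit, and the step of an at least 1.1-fold higher number from compound 1 to compound 2 (0.07 log units; that floor lies within the scatter), carbamoyl in place of chloro, ended there too. With both floors inside the scatter, no step beyond the scatter is expected for a number no higher from compound 3 to compound 4 (the limit leaves the size open), and a limit is again the expected outcome. Compound 4 is estimated at 25000 nM, between 14000 nM and 60000 nM.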

Compound 4, half-maximal effective concentration: > 25000 nM
Compound 4 was reported as a limit; the forecaster's own chance of this, stated with the estimate: 65%; the middle value sits exactly at the limit.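

In this assay, fluoro in place of chloro on an aromatic carbon gives an at least 1.1-fold higher number from compound 1 to compound 4 (0.07 log units; that floor lies within the scatter). Chloro, carbamoyl and fluoro have now been compared at this place, and no step among compound 1, compound 2 and compound 4 is shown beyond the scatter. The steps from compound 2 and from compound 3 to compound 4 cannot be read, because both ends of each are limits: the limit of > 25000 nM in this assay, at which 3 of the 4 values shown sit.

Going by these compounds, the numbers behind the limits of compound 2, compound 3 and compound 4 stay open. So does whether an amine or a carboxylic acid on this aromatic carbon would give a number rather than a limit in this assay.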